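The source may hold more compounds than are shown below. What is called first, only, known or untested is meant among the compounds shown, and "the series" means these compounds.

The measured compounds in an assay on HEK293 cells for inhibition of Steryl-sulfatase (Homo sapiens), tested at 1 uM; a lower number here means a weaker effect, a higher number a stronger effect of the compound at the concentration tested:
compound 1 `CN(C)CCN(CCN(C)C)c1cccc(C(=O)N2CCc3ccc(OS(N)(=O)=O)cc3C2)c1` gives 17.1%
compound 2 `CCN(Cc1cccc(Br)c1)c1ccc(C(=O)N2CCc3ccc(OS(N)(=O)=O)cc3C2)cc1` gives 97.2%
compound 3 `NS(=O)(=O)Oc1ccc2c(c1)CN(C(=O)c1cccc(N(Cc3ccccc3)Cc3ccco3)c1)CC2` gives 90.5%

Compound 2 stands at the highest of these three numbers in this assay, though compound 3 lies close enough to it to be within the usual scatter, so the two cannot be ranked against each other. Compound 1 is far below compound 2, by a gap well beyond the scatter.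

The step to be followed goes from compound 2 to compound 4 `CN(CCN1CCCCC1)c1ccc(C(=O)N2CCc3ccc(OS(N)(=O)=O)cc3C2)cc1`, which has not yet been measured in this assay. The change is methyl(2-(piperidin-1-yl)ethyl)amino in place of (3-bromobenzyl)(ethyl)amino on an aromatic carbon, on a carbon of the ring that sits para to a large group.

No step between measured compounds is given for this change, so what is expected rests on the three numbers shown. Compound 1, whose ring carries an amino group bearing two dimethylaminoethyl chains rather than benzyl groups, gives only 17.1%, while compound 2 and compound 3, each with a benzyl-type group on the amino nitrogen, give the high numbers. Compound 4 again carries an amino-ethyl chain, so a drop beyond the scatter is expected in this assay, estimated as a number 52.2 percentage points lower from compound 2 to compound 4 (beyond the scatter). Compound 4 is estimated at 45%, with a range from 15% to 80%.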

Compound 4, a percentage reported as inhibition, at one concentration (the size of the read-out at that concentration, not a potency): 26.8%
The estimate for compound 4 lay 18.2 percentage points above the measured number; measured number inside the range.
By their numbers in this assay, from the lowest: compounds 1 and 4 (each within the scatter of the next); then compounds 3 and 2 (each within the scatter of the next).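

In this assay, placing methyl(2-(piperidin-1-yl)ethyl)amino instead of (3-bromobenzyl)(ethyl)amino on the aromatic carbon para to a large group gives a number 70.4 percentage points lower from compound 2 to compound 4 (beyond the scatter), the first step shown at this position, so with the rest of the molecule unchanged, the group held there decides whether the inhibition is high or low. The change is not a single feature, however: the entering group gives up the six-membered aromatic ring of carbon only and the bromine, and brings a six-membered non-aromatic ring with one hetero atom and a second nitrogen, with compound 4 at 26.8%. Nothing measured alongside this step gives a reason for the drop.

Which of these differences accounts for the step stays open, as the ring, the bromine and the alkyl groups on the amino nitrogen all change together. A 3-chlorobenzyl group in place of the 3-bromobenzyl, or a morpholine ring at the end of the ethyl chain in place of the piperidine, would each test one part of the change, and a read-out at a single concentration leaves the potency of these compounds open as well.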